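Swapping the piperazine substituent in a cytotoxicity series

A few compounds are considered here, and "the series" means these few. Any claim that something is new, unique, unknown or untested is made for them only; others in the source may bear on it.

Measured compounds:
Compound 1, `CN1CCN(CC(=O)Nc2ccc(-c3nc(-c4ccccc4)c(-c4ccccc4)n3C)cc2)CC1` — 1.1%
Compound 2, `CCN1CCN(CC(=O)Nc2ccc(-c3nc(-c4ccccc4)c(-c4ccccc4)n3C)cc2)CC1` — 4.7%

Both compounds were tested in a functional assay on MCF7 cells (Homo sapiens) for cytotoxicity, read by MTT assay, with a stated time of 24 h, tested at 0.64 ug/mL; on this read-out lower numbers stand for a weaker effect and higher numbers for a stronger effect at the one concentration tested. Compound 1 gives 1.1%, and compound 2 gives 4.7%, so the two numbers are within the scatter of each other: neither can be called the stronger. For the measured compounds named here, the only step seen so far, a number 3.6 percentage points higher from compound 1 to compound 2 (within the scatter), does not separate the two compounds.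

Compound 3, `CN(C)/C=C/N1CCN(CC(=O)Nc2ccc(-c3nc(-c4ccccc4)c(-c4ccccc4)n3C)cc2)CC1`, has not yet been measured. It differs from compound 2 at the same ring nitrogen that was changed between compound 1 and compound 2: 2-(dimethylamino)ethenyl in place of ethyl on an amine nitrogen in a ring.

Going by the values given here, the one step that bears on this change is the earlier exchange at this nitrogen, which stayed within the scatter. Among the compounds with values here, nothing beyond that has been observed here, and the entering group has no precedent among the measured compounds. The expected step of a number 0.3 percentage points higher from compound 2 to compound 3 (within the scatter) is therefore none beyond the scatter, in no particular direction. Compound 3 is estimated at 5%, with a range from 0% to 20%.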

Compound 3, a percentage reported as activity, at one concentration (the size of the read-out at that concentration, not a potency): 1.2%
Compound 3: middle estimate off by 3.8 percentage points, on the high side, within the range that was stated.
By their numbers in this assay, from the lowest: compounds 1, 3 and 2 (each within the scatter of the next).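

Placing 2-(dimethylamino)ethenyl on the amine nitrogen in the ring, in place of ethyl, gives in this assay a number 3.5 percentage points lower from compound 2 to compound 3 (within the scatter) and, in place of methyl, gives a number 0.1 percentage points higher from compound 1 to compound 3 (within the scatter) in the same test. The earlier pair covered only methyl and ethyl, whereas the entering group brings 5 heavy atoms, a nitrogen, a double bond outside aromatic rings and a hydrogen-bond acceptor, and among these three compounds even this larger exchange does not separate any pair in this assay. Nothing measured here explains why the read-out stays within the scatter across these groups.

The compounds shown leave open whether a different kind of group on this nitrogen, such as benzyl, acetyl or a longer chain ending in a carboxylic acid, would produce a step beyond the scatter. They also leave open how these three compounds would compare at higher concentrations, since the read-out here comes from a single concentration and says nothing about potency.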